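Swapping ethyl for cyanomethyl in compound 1

This account rests on a few compounds, and the source may have more. Where it says the series, first, only, none or still open, it means among the compounds named here.

Compound 1 `CC[C@H](NC(=O)[C@H](COC)NC(=O)c1cc(C)on1)C(=O)N[C@@H](CC(C)C)C(=O)[C@@]1(C)CO1`: 92 nM
Compound 2 `Cc1cc(C(=O)N[C@@H](CC(C)C)C(=O)N[C@@H](CCc2ccccc2)C(=O)N[C@@H](CC(C)C)C(=O)[C@@]2(C)CO2)n[nH]1`: 103 nM

In a functional assay on MES-SA cells (Homo sapiens) for cytotoxicity, read by luminescence and CellTiter-Glo, with a stated time of 72 h (a lower number here means a stronger inhibitor, a higher number a weaker inhibitor), compound 1 gives 92 nM and compound 2 gives 103 nM. These two values lie within the usual scatter, so compound 1 stands level with compound 2.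

Compound 3 `COC[C@H](NC(=O)c1cc(C)on1)C(=O)N[C@@H](CC#N)C(=O)N[C@@H](CC(C)C)C(=O)[C@@]1(C)CO1` keeps the rest of compound 1 but carries one change: cyano in place of methyl on a saturated chain carbon, two bonds along the chain from an amide-type nitrogen and a carbonyl carbon. This places cyano in place of methyl on a saturated chain carbon, two bonds along the chain from an amide-type nitrogen and a carbonyl carbon, so ethyl becomes cyanomethyl.

Among the measured compounds shown here, no two measured compounds differ in one place only, so the data give no direct size for such a change. Compound 2 has a quite different structure yet gives 103 nM, so only a modest move is expected, towards a higher number and weaker inhibition. The expected change is a 2.2-fold higher number from compound 1 to compound 3 (0.34 log units; beyond the scatter). For compound 3 the estimated value is 200 nM, with an expected range from 70 nM to 600 nM.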

Compound 3, half-maximal inhibitory concentration: 29 nM
Compound 3: the middle estimate sits 6.9-fold (0.84 log units) above what was measured, and the stated range ends above it.
By their numbers in this assay, from the lowest: compound 3; then compounds 1 and 2 (each within the scatter of the next).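

In this assay, among the compounds shown here, the swap of ethyl for cyanomethyl brings a 3.2-fold lower number from compound 1 to compound 3 (0.50 log units; beyond the scatter) and gives the first direct reading of a single change at this position. The step is modest, but it shows that this saturated chain carbon, two bonds along the chain from an amide-type nitrogen and a carbonyl carbon, can carry cyano in place of methyl with a gain rather than a loss in inhibition. Nothing in the data explains why the number falls.

Only this one replacement is shown, so it remains open whether the nitrile itself matters or whether a hydroxymethyl group, an aminomethyl group or a longer chain ending in a nitrile would do the same. As far as these compounds go, it is also open whether the swap would give a similar step on a different core, such as that of compound 2.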